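From ethoxycarbonyl to 2-phenylethenyl on compound 3

This account rests on a few compounds, and the source may have more. Where it says the series, first, only, none or still open, it means among the compounds named here.

In a functional assay on NALM-6 cells (Homo sapiens) for cytotoxicity, with a stated time of 72 h (on this read-out lower numbers stand for an effect already at smaller amounts and higher numbers for an effect only at larger amounts of compound), compound 3 (`C=C[C@@](C)(/C=C/c1ccc(O)c(/C=C/C(=O)OCC)c1)CCC=C(C)C`) gives 20900 nM and lies within the scatter of compound 2 (`C=C[C@@](C)(/C=C/c1ccc(O)c(C=O)c1)CCC=C(C)C`) at 11200 nM on the numbers shown. The measured step that joins them is a 1.9-fold higher number from compound 2 to compound 3 (0.27 log units; within the scatter) and it places 2-(ethoxycarbonyl)ethenyl where formyl stood on an aromatic carbon. For compound 1 (`C=C[C@@](C)(/C=C/c1ccc(O)cc1)CC/C=C/C(=O)OCC`) this assay returns > 43400 nM as a limit and not as a number.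

Compound 4 (`C=C[C@@](C)(/C=C/c1ccc(O)c(/C=C/C=C/c2ccccc2)c1)CCC=C(C)C`) departs from compound 3 at the end of that same substituent. The change is 2-phenylethenyl in place of ethoxycarbonyl on a double-bonded chain carbon bound to a double-bonded chain carbon with 2-phenylethenyl in place of ethoxycarbonyl on a double-bonded chain carbon bound to a double-bonded chain carbon.

Going by the values given here, only one measured step bears on this substituent, namely a 1.9-fold higher number from compound 2 to compound 3 (0.27 log units; within the scatter) and it stayed within the scatter. Among the compounds with values here, no measured step shows what happens when ethoxycarbonyl itself is replaced, so the expectation rests on that single small step. No change beyond the scatter is therefore expected in this assay and no direction is claimed. The estimated size is a 1.3-fold lower number from compound 3 to compound 4 (0.12 log units; within the scatter) as an expected step inside the scatter. For compound 4 the estimated value is 16000 nM with an expected range from 6500 nM to 40000 nM for repeated measurements.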

Compound 4, half-maximal effective concentration: > 43400 nM
Compound 4: a limit, no number; the forecaster's own chance of this, stated with the estimate: 15%; middle value at least 2.7-fold (0.43 log units) away from the limit.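

On a double-bonded chain carbon bound to a double-bonded chain carbon, 2-phenylethenyl in place of ethoxycarbonyl gives an at least 2.0-fold higher number from compound 3 to compound 4 (0.31 log units; beyond the scatter) in this assay, and this is the only step shown on this substituent that lies beyond the scatter. Going by these compounds alone, the one earlier step on the substituent, a 1.9-fold higher number from compound 2 to compound 3 (0.27 log units; within the scatter), stayed within the scatter, and it could not show that the group at the far end of the chain bears on this read-out, as the present step does. Compound 4 returns a limit and not a number, so the step has a lower bound but no measured size: the limit of > 43400 nM in this assay, at which 2 of the 4 values shown sit.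

The compounds shown leave open whether a carboxylic acid, an amide or a methyl ester in place of ethoxycarbonyl would stay within the scatter of compound 3 or move as 2-phenylethenyl does. They also leave open whether a plain phenyl group, with its aromatic ring but without the ethenyl link, would give a number in this assay or the same limit as compound 4.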